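Replacing Phenylethenyl with Trifluoromethoxy on the Sulfonamide Core

The source may hold more compounds than are shown below. What is called first, only, known or untested is meant among the compounds shown, and "the series" means these compounds.

Compound 3 `C=C(c1ccccc1)c1cccc(N(Cc2cccnc2)S(=O)(=O)CC)c1` gives 200 nM in an assay on isolated protein with metabotropic glutamate receptor 2 (Homo sapiens) as the target (on this read-out lower numbers stand for an effect already at smaller amounts and higher numbers for an effect only at larger amounts of compound), the lowest of the two numbers obtained here. Compound 2 `C=C(c1ccccc1)c1ccc(N(Cc2cccnc2)S(=O)(=O)CC)cc1` gives 780 nM in this assay, a higher number that lies beyond the usual scatter. For compound 1 `CCS(=O)(=O)N(Cc1cccnc1)c1ccc(C(O)c2ccccc2)cc1`, this assay reports only a limit, > 30000 nM, not a number. Compound 4 `CCS(=O)(=O)N(Cc1cccnc1)c1cccc(OC(F)(F)F)c1` is compound 3 with trifluoromethoxy in place of 1-phenylethenyl on an aromatic carbon. Among the measured compounds shown here, the one measured step that bears on this change is an at least 38-fold lower number from compound 1 to compound 2 (1.58 log units; beyond the scatter). Compound 1 sat at the limit of > 30000 nM in this assay, at which 1 of the 3 values shown sits, before the 1-phenylethenyl group was present. Taking that group away again is therefore expected to raise the number markedly, an estimated step of a 20-fold higher number from compound 3 to compound 4 (1.30 log units; beyond the scatter). Compound 4 is expected to give about 4000 nM, within 700 nM to 25000 nM.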

Compound 4, half-maximal effective concentration: 1600 nM
Compound 4: the middle estimate sits 2.5-fold (0.40 log units) above what was measured; the measured number falls inside the stated range.
By their numbers in this assay, from the lowest: compound 3; then compound 2; then compound 4. At a limit, above all of these: compound 1.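

Trifluoromethoxy in place of 1-phenylethenyl brings an 8.0-fold higher number from compound 3 to compound 4 (0.90 log units; beyond the scatter), so this change costs something at this place. Even so, compound 4, whose new group has no ring, still gives a number in this assay and not a limit, so a ring in this group is not needed for a measurable number. Only compound 1 stays at a limit, not a number: the limit of > 30000 nM in this assay, at which 1 of the 4 values shown sits.

As far as these compounds go, it remains open how a methoxy group or an amine on this aromatic carbon would compare. A plain phenyl or benzyl group would be needed to separate the part played by the ring from that of the double bond in 1-phenylethenyl.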